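From Chloro to Azido on a Shared Core

A few compounds are considered here, and "the series" means these few. Any claim that something is new, unique, unknown or untested is made for them only; others in the source may bear on it.

In a functional assay on MGC-803 cells (Homo sapiens) for inhibition, read by MTT assay, with a stated time of 48 h (on this read-out lower numbers stand for stronger inhibition and higher numbers for weaker inhibition), compound 1 `COc1ccc(CN(C(=O)C=C(C)C)c2cc(OC)c(OC)c(OC)c2)cc1O` gives 320 nM, while compound 2 `COc1ccc(CN(C(=O)CCl)c2cc(OC)c(OC)c(OC)c2)cc1O` gives 84 nM, the lower of the two numbers. Compound 3 `COc1ccc(CN(C(=O)CN=[N+]=[N-])c2cc(OC)c(OC)c(OC)c2)cc1O` carries azido in place of chloro on a saturated chain carbon bound to a carbonyl carbon. Within the data shown here, the only measured step, a 3.8-fold lower number from compound 1 to compound 2 (0.58 log units; beyond the scatter), put chloromethyl in place of 2-methylprop-1-en-1-yl on a carbonyl carbon, so it bears only loosely on this change. A step no larger than that one, toward a higher number, is expected in this assay, estimated as a 1.9-fold higher number from compound 2 to compound 3 (0.28 log units; within the scatter). For compound 3 the estimate is 160 nM, with an expected range from 45 nM to 550 nM.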

Compound 3, half-maximal inhibitory concentration: 120 nM
Compound 3: the middle estimate sits 1.3-fold (0.12 log units) above what was measured; measured number inside the range.
By their numbers in this assay, from the lowest: compounds 2 and 3 (each within the scatter of the next); then compound 1.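

In this assay, azido in place of chloro on a saturated chain carbon bound to a carbonyl carbon gives a 1.4-fold higher number from compound 2 to compound 3 (0.15 log units; within the scatter) and so the two groups cannot be told apart here. Replacing the 2-methylprop-1-en-1-yl group with azidomethyl gives a 2.7-fold lower number from compound 1 to compound 3 (0.43 log units; beyond the scatter) and so a lower number than that of compound 1 does not depend on chloro alone. No measurement shown explains why these two groups read alike. Still open, as far as these compounds go, is whether an amine or a hydroxy group on that same carbon would read like chloro and azido. From the compounds shown here alone, a longer chain carrying azido is equally open.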